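This account rests on a few compounds, and the source may have more. Where it says the series, first, only, none or still open, it means among the compounds named here.

In an ADME assay on HepG2 2.2.15 cells (Homo sapiens) for cytotoxicity, read by MTT assay, with a stated time of 72 h (a higher number here means that more compound is tolerated, a lower number that less compound is tolerated), compound 2 `Cc1cc(C)cc(Cc2nc(SCc3ccc([N+](=O)[O-])cc3)[nH]c(=O)c2I)c1` gives 39000 nM, and compound 3 `O=c1[nH]c(SCc2ccc([N+](=O)[O-])cc2)nc(Cc2ccccc2)c1I` gives 52700 nM. Compound 1 `CC1CCN(Cc2nc(SCc3ccc(C#N)cc3)[nH]c(=O)c2I)CC1` is reported in this assay only as a limit, > 100000 nM, not as a number; this is the limit of > 100000 nM in this assay, at which 1 of the 3 values shown sits. Among the two numbers shown, compound 3 carries the higher one, yet its nearest neighbour is compound 2, and the single measured step between them, a 1.4-fold higher number from compound 2 to compound 3 (0.13 log units; within the scatter), lies within the scatter of this assay, so the two cannot be told apart.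

Compound 4 `O=c1[nH]c(SCc2ccc([N+](=O)[O-])cc2)nc(Cc2cc(F)cc(F)c2)c1I` has not yet been measured. It differs from compound 3 in one place: 3,5-difluorophenyl in place of phenyl on a saturated chain carbon bound to an aromatic carbon. Within the data shown here, the only measured step that touches this same position is the one from compound 2 to compound 3, where a substituted phenyl gave way to the bare one and the number barely moved. On that evidence a change of the substituents on this phenyl has not produced a shift beyond the scatter, and none beyond the scatter is expected here either: the step from compound 3 to compound 4 is estimated as a 1.1-fold lower number from compound 3 to compound 4 (0.02 log units; within the scatter). Compound 4 is therefore expected to give about 50000 nM in this assay, with a plausible range from 25000 nM to 100000 nM.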

Compound 4, half-maximal cytotoxic concentration: > 100000 nM
Compound 4 ended at the assay's limit; the forecaster's own chance of this, stated with the estimate: 15%; middle value at least 2.0-fold (0.30 log units) away from the limit.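

In this assay, compound 4 is reported only as a limit and not as a number: the limit of > 100000 nM in this assay, at which 2 of the 4 values shown sit.

Against the bare phenyl, 3,5-difluorophenyl gives an at least 1.8-fold higher number from compound 3 to compound 4 (0.27 log units; that floor lies within the scatter), so this floor alone does not separate the two, although the limit leaves room for a larger step. Against 3,5-dimethylphenyl, the same group gives an at least 2.5-fold higher number from compound 2 to compound 4 (0.40 log units; beyond the scatter), and this is the first step on this saturated chain carbon bound to an aromatic carbon that is shown to lie beyond the scatter. The earlier step between the substituted and the bare phenyl had suggested that this position made no detectable difference, whereas this pair shows that exchanging 3,5-dimethylphenyl for 3,5-difluorophenyl can move the number in this series.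

From the compounds shown here alone, the true size of both steps remains open, since the limit gives only their floors. Going by these compounds, it also remains open whether 3,5-dichlorophenyl, or a phenyl carrying a carboxylic acid, would behave like 3,5-difluorophenyl or like 3,5-dimethylphenyl at this position.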